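The source may report more compounds than this note shows. Statements on the series, on what has been measured and on what is new or still open speak of the compounds shown alone.

Working notes on the series. The shared core appears in compound 1 `NC1=C(C(=O)c2ccccc2)C(c2ccc(Br)cc2)N(CCCn2ccnc2)C1=O`, which in a functional assay on SAOS-2 cells (Homo sapiens) for antiproliferative activity, read by MTT assay, with a stated time of 72 h (on this read-out lower numbers stand for stronger inhibition and higher numbers for weaker inhibition), gives 107000 nM. Compound 2 `CCOc1ccc(NC2=C(C(=O)c3ccccc3)C(c3ccc(Br)cc3)N(CCCn3ccnc3)C2=O)cc1` gives 30900 nM, and compound 3 `O=C(C1=C(Nc2ccc(Cl)cc2)C(=O)N(CCCn2ccnc2)C1c1ccc(Br)cc1)c1ccccc1` gives 24800 nM. Compound 3 holds the lowest number of the three, though only its distance from compound 1 is beyond the scatter. Compound 4 `O=C(C1=C(Nc2cccc(Br)c2)C(=O)N(CCCn2ccnc2)C1c1ccc(Br)cc1)c1ccccc1` differs from compound 3 by 3-bromophenyl in place of 4-chlorophenyl on an amine nitrogen. The step that bears on this is a 1.2-fold lower number from compound 2 to compound 3 (0.10 log units; within the scatter), a swap of aromatic substituents on the same aryl group that stayed within the scatter; the steps of a 3.5-fold lower number from compound 1 to compound 2 (0.54 log units; beyond the scatter) and a 4.3-fold lower number from compound 1 to compound 3 (0.63 log units; beyond the scatter) concern adding the aryl group itself and are larger. In this assay no step beyond the scatter is therefore expected. Compound 4 is estimated at 25000 nM, range 10000 nM to 60000 nM, meaning a 1.0-fold higher number from compound 3 to compound 4 (0.00 log units; within the scatter).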

Compound 4, half-maximal inhibitory concentration: 9090 nM
Compound 4: middle estimate off by 2.8-fold (0.44 log units), on the high side, outside the stated range (below it).
By their numbers in this assay, from the lowest: compound 4; then compounds 3 and 2 (each within the scatter of the next); then compound 1.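

In this assay, the choice of aryl group on this amine nitrogen now matters: a 2.7-fold lower number from compound 3 to compound 4 (0.44 log units; beyond the scatter) is beyond the scatter, whereas the earlier swap between 4-ethoxyphenyl and 4-chlorophenyl stayed within it. 3-Bromophenyl also stands clear of 4-ethoxyphenyl, with a 3.4-fold lower number from compound 2 to compound 4 (0.53 log units; beyond the scatter), and it gives the largest step in the series over hydrogen, with a 12-fold lower number from compound 1 to compound 4 (1.07 log units; beyond the scatter). No available evidence explains this difference. The compounds shown leave open whether the change of halogen or its changed place on the phenyl carries the step; 4-bromophenyl and 3-chlorophenyl on this nitrogen would separate the two.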